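The source may hold more compounds than are shown below. What is called first, only, known or untested is meant among the compounds shown, and "the series" means these compounds.

Series notes. The shared core is compound 1 `O=C1C=CC(=O)c2ncncc21`, which in a functional assay on MIA PaCa-2 cells (Homo sapiens) for cytotoxicity, read by MTT assay, with a stated time of 72 h (on this read-out lower numbers stand for stronger inhibition and higher numbers for weaker inhibition), gives 9400 nM. Compound 2 `O=C1C(Nc2ccc(Oc3ccccc3)cc2)=CC(=O)c2ncncc21` is a substituted member of the same core; in this assay compound 2 gives 3700 nM. Compound 3 `COc1ccc(NC2=CC(=O)c3ncncc3C2=O)cc1OC` is the other substituted member, and in this assay compound 3 gives 1800 nM. Among the three numbers compound 2 stands second highest: compound 1 gives a higher number and compound 3 a lower one, and both gaps lie beyond the usual scatter.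

Compound 4 `O=C1C(Nc2ccc(-c3ccccc3)cc2)=CC(=O)c2ncncc21` has not yet been measured. It differs from compound 2 in one place: phenyl in place of phenoxy on an aromatic carbon. Among the compounds with values here, no measured pair shows this change, so the data give no direction for it. For compound 4 the expected step is a 1.1-fold lower number from compound 2 to compound 4 (0.02 log units; within the scatter), which amounts to none beyond the scatter in either direction. On that basis compound 4 is estimated at 3500 nM in this assay, with a range from 1200 nM to 10000 nM.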

Compound 4, half-maximal inhibitory concentration: 900 nM
Estimate against measurement, compound 4: 3.9-fold (0.59 log units) above, outside the stated range (below it).
By their numbers in this assay, from the lowest: compounds 4 and 3 (each within the scatter of the next); then compound 2; then compound 1.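

On the aromatic carbon para to a large group, phenyl in place of phenoxy gives a 4.1-fold lower number from compound 2 to compound 4 (0.61 log units; beyond the scatter) in this assay and so supplies the first direction for this change. The result shows that this position responds to the group it carries, even though both groups hold one six-membered aromatic ring of carbon only and differ by one oxygen, which is also their one hydrogen-bond acceptor. No measurement on hand bears on the reason for the step.

As far as these compounds go, this change rests on a single pair, so whether it carries over to other members remains open. Also open, from the compounds shown here alone, is how a benzyl group, an amine or a carboxylic acid on the same aromatic carbon would compare with phenyl.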